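Methoxy to ethoxy: from compound 3 to compound 4

The source may report more compounds than this note shows. Statements on the series, on what has been measured and on what is new or still open speak of the compounds shown alone.

In an ADME assay on RAW264.7 cells (Mus musculus) for cytotoxicity, read by MTT assay, with a stated time of 24 h, in the presence of a further agent that is not named here (on this read-out higher numbers stand for weaker inhibition and lower numbers for stronger inhibition), compound 1 `O=C1OC(Cc2nc(Cc3ccccc3)no2)c2ccccc21` gives > 40000 nM, which is a limit and not a number. Compound 2 `COc1cc(OC)c2c(c1)C(C(O)c1ccc(O)cc1)OC2=O` gives > 40000 nM, again a limit. Compound 3 `COc1ccc(C(O)C2OC(=O)c3c(OC)cc(OC)cc32)cc1` gives > 40000 nM, also a limit. Compound 3 therefore has no numerical position of its own and shares with the other two compounds (the limit of > 40000 nM in this assay, at which 3 of the 3 values shown sit).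

Compound 4 `CCOc1ccc(C(O)C2OC(=O)c3c(OC)cc(OC)cc32)cc1` departs from compound 3 by one change: methyl in place of hydrogen on a saturated chain carbon bound to an oxygen on an aromatic ring. In words, this is methyl in place of hydrogen on a saturated chain carbon bound to an oxygen on an aromatic ring, or methoxy to ethoxy.

The closest measured comparison is a step that the two limits leave unreadable from compound 2 to compound 3, where methyl takes the place of hydrogen on an oxygen on an aromatic ring. Among the compounds with values here, it gives no size to carry forward, and the series holds no measured step of readable size. The expectation in this assay is therefore no shift beyond the usual scatter, with another limit the most likely report. The expected step is a number no higher from compound 3 to compound 4 (the limit leaves the size open). For compound 4 the estimated value is 40000 nM, with an expected range of 20000 nM to 80000 nM.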

Compound 4, half-maximal inhibitory concentration: > 40000 nM
Compound 4 ended at the assay's limit (the forecaster's own chance of this, stated with the estimate: 85%); the middle value lies on the limit itself.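

No new step can be read among compound 2, compound 3 and compound 4 in this assay, because each result is a limit and not a number: the limit of > 40000 nM in this assay, at which 4 of the 4 values shown sit.

The compounds shown leave open whether any change on the oxygen on an aromatic ring shifts this read-out, and at what concentration any of them would reach half-maximal inhibition.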